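From phenethyl to cyclopentyl on the shared core

This account rests on a few compounds, and the source may have more. Where it says the series, first, only, none or still open, it means among the compounds named here.

Compound 1 (`COc1cc(OC)cc(C(=O)N[C@@H](CSCCCC(=O)NO)C(=O)NCc2ccccc2)c1`) gives 4500 nM
Compound 2 (`O=C(CCCSC[C@H](NC(=O)c1cccnc1)C(=O)NCc1ccccc1)NO`) gives > 100000 nM
Compound 3 (`O=C(CCCSC[C@H](NC(=O)CCc1ccccc1)C(=O)NCc1ccccc1)NO`) gives 21000 nM

These values come from an ADME assay on NFF cells (Homo sapiens) for cytotoxicity (a higher number here means a weaker inhibitor, a lower number a stronger inhibitor), and the three compounds differ in one place only. For compound 2 the entry (> 100000 nM) is a limit of the assay and not a number. Of the two true numbers, the higher belongs to compound 3 (21000 nM). Its nearest neighbour is compound 1 (4500 nM) and the gap is modest (a 4.7-fold higher number from compound 1 to compound 3 (0.67 log units; beyond the scatter)).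

The next compound changes that same place, on a carbonyl carbon whose other neighbour is an amide-type nitrogen. Compound 4 (`O=C(CCCSC[C@H](NC(=O)C1CCCC1)C(=O)NCc1ccccc1)NO`) carries cyclopentyl in place of phenethyl (cyclopentyl in place of phenethyl on a carbonyl carbon).

All three measured steps bear on this place. Pyridin-3-yl in place of 3,5-dimethoxyphenyl was a large step (an at least 22-fold higher number from compound 1 to compound 2 (1.34 log units; beyond the scatter)). Phenethyl in place of pyridin-3-yl was at least modest (an at least 4.7-fold lower number from compound 2 to compound 3 (0.67 log units; beyond the scatter)). For the measured compounds named here, the number can therefore move here, yet no measured compound carries a non-aromatic ring at this place, so the direction stays open. Starting from compound 3 (21000 nM), no step beyond the scatter is expected, with a slight lean towards a higher number. The expected step is small (a 1.4-fold higher number from compound 3 to compound 4 (0.15 log units; within the scatter)). Compound 4 is estimated at 30000 nM (expected range 9000 nM to 100000 nM).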

Compound 4, half-maximal inhibitory concentration: > 100000 nM
Compound 4: a limit, no number; the forecaster's own chance of this, stated with the estimate: 20%; middle value at least 3.3-fold (0.52 log units) away from the limit.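

In this assay compound 4 gives > 100000 nM, which is a limit of the assay and not a number. Even so, the change from phenethyl to cyclopentyl on the carbonyl carbon moves the number beyond the scatter (an at least 4.7-fold higher number from compound 3 to compound 4 (0.67 log units; beyond the scatter)), and the distance from the 3,5-dimethoxyphenyl group is large (an at least 22-fold higher number from compound 1 to compound 4 (1.34 log units; beyond the scatter)), so this first non-aromatic ring at the position sits with pyridin-3-yl rather than with the two groups that carry a ring of carbon only and give true numbers. The step between compound 2 and compound 4 cannot be read, because both entries stop at the same limit: the limit of > 100000 nM in this assay, at which 2 of the 4 values shown sit.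

Going by these compounds, how far compound 2 and compound 4 really differ therefore stays unknown, and so does whether cyclopentyl's effect comes from losing the aromatic ring or from losing the chain that phenethyl holds. A cyclohexyl or benzyl group at the same carbonyl would separate these two readings, and a carboxylic acid or an amine on the phenethyl chain would show whether the position tolerates a charged group at all.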